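Carboxymethyl replaces the phosphorus-bearing group of compound 2

The compounds below may be only part of what the source reports. "The series", "measured", "known", "first", "only" and "open" are said of these compounds alone.

In a physicochemical assay for solubility, at pH 7.4 (on this read-out higher numbers stand for higher solubility and lower numbers for lower solubility), compound 1 (`COCc1nc(Nc2ccc(C(F)(F)F)cc2)c2ccc(-c3ncccc3C(F)(F)F)cc2n1`) gives 0.2 ug/mL. Compound 2 (`O=P(O)(O)OCc1nc(Nc2ccc(C(F)(F)F)cc2)c2ccc(-c3ncccc3C(F)(F)F)cc2n1`) gives > 138 ug/mL, which is a limit of the assay and not a number. On these figures compound 2 therefore stands only at a limit: the limit of > 138 ug/mL in this assay, at which 1 of the 2 values shown sits.

Compound 3 (`O=C(O)CCc1nc(Nc2ccc(C(F)(F)F)cc2)c2ccc(-c3ncccc3C(F)(F)F)cc2n1`) has not yet been measured. It differs from compound 2 by a group of 4 heavy atoms (2 carbon, 2 oxygen; no ring) in place of a group of 5 heavy atoms (4 oxygen, 1 phosphorus; no ring), on a saturated chain carbon bound to an aromatic carbon. For the measured compounds named here, one measured step bears on this change: an at least 690-fold higher number from compound 1 to compound 2 (2.83 log units; beyond the scatter). That large step introduced the phosphorus-bearing group, which is absent from compound 3. Going by the values given here, no measured step shows what carboxymethyl does on the shared core, so the comparison is indirect. Going by compound 2 and its step of an at least 690-fold higher number from compound 1 to compound 2 (2.83 log units; beyond the scatter), a moderate to large fall in this assay is expected, with only part of that earlier gain lost. The estimated change is an at least 4.6-fold lower number from compound 2 to compound 3 (0.66 log units; beyond the scatter). For compound 3 the expected value is 30 ug/mL, with an estimated range of 5 ug/mL to 130 ug/mL.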

Compound 3, solubility: 125 ug/mL
Estimate against measurement, compound 3: 4.2-fold (0.62 log units) below; measured number inside the range.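

In this assay, the compounds now show that a large rise over compound 1 is not confined to the phosphorus-bearing group: carboxymethyl in place of methoxy, on a saturated chain carbon bound to an aromatic carbon, comes with a 630-fold higher number from compound 1 to compound 3 (2.80 log units; beyond the scatter). Set against the phosphorus-bearing group at the same place, the exchange reads as an at least 1.1-fold lower number from compound 2 to compound 3 (0.04 log units; that floor lies within the scatter), so the two groups cannot be ranked on these figures, and the true gap between them could be negligible or large. Compound 2 is held at a limit of the assay and not at a number, which is all that can be said of its side of this comparison: the limit of > 138 ug/mL in this assay, at which 1 of the 3 values shown sits.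

The compounds shown leave open whether an amine, a primary amide or a sulfonic acid at this place would stand near compound 3 or near compound 1, and whether a longer chain ending in a carboxylic acid would keep the value of compound 3. They also leave open how far compound 2 really lies from compound 3, and whether carboxymethyl would bring a similar rise on a core changed elsewhere.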